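The compounds below may be only part of what the source reports. "The series", "measured", "known", "first", "only" and "open" are said of these compounds alone.

Compound 1 `CCC1=C(O)c2c(oc(-c3ccc(SC)cc3)cc2=O)C(CC)(CC)C1=O` was run in a functional assay on KB cells (Homo sapiens) for antiproliferative activity, read by sulforhodamine B assay, with a stated time of 3 days; a lower number here means that less compound is needed, a higher number that more compound is needed for the effect. In this assay compound 1 gives > 52.1 uM, which is a limit of the assay and not a number. Compound 2 `CCC1=C(O)c2c(oc(-c3ccc(COC)cc3)cc2=O)C(CC)(CC)C1=O` gives > 52.4 uM in this assay, again a limit rather than a number. Compound 3 `CCC1=C(O)c2c(oc(-c3ccc(C)c(Cl)c3)cc2=O)C(CC)(CC)C1=O` gives 39 uM in this assay.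

Among the three measured compounds, compound 3 is the only one with a number; the other two stand at limits, as shown by the limit of > 52.1 uM in this assay, at which 1 of the 3 values shown sits, and (the limit of > 52.4 uM in this assay, at which 1 of the 3 values shown sits). The step from compound 1 to compound 2 is a step that the two limits leave unreadable from compound 1 to compound 2. The step from compound 1 to compound 3 is an at least 1.3-fold lower number from compound 1 to compound 3 (0.12 log units; that floor lies within the scatter), and the step from compound 2 to compound 3 is an at least 1.3-fold lower number from compound 2 to compound 3 (0.12 log units; that floor lies within the scatter); both are floors that lie within the scatter.

Compound 4 `CCC1=C(O)c2c(oc(-c3cc(C)cc(C)c3)cc2=O)C(CC)(CC)C1=O` has not yet been measured. It differs from compound 3 in this way: 3,5-dimethylphenyl in place of 3-chloro-4-methylphenyl on an aromatic carbon. Going by the values given here, no measured step exchanges one substituted phenyl for another of this kind, and the two steps that reach compound 3 only set floors within the scatter. The expectation for this assay is therefore no step beyond the scatter, so the estimated step is a 1.0-fold higher number from compound 3 to compound 4 (0.01 log units; within the scatter). Compound 4 is expected to give about 40 uM, within 15 uM to 120 uM.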

Compound 4, concentration for half-maximal effect: 45.5 uM
For compound 4 the middle estimate is 1.1-fold (0.06 log units) below the measured one, within the range that was stated.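

At this position, on the aromatic carbon next to the ring oxygen, the result gives a second number in this assay, and the exchange of 3-chloro-4-methylphenyl for 3,5-dimethylphenyl, which swaps a group with one chlorine for one of carbon only with the same count of heavy atoms, is a 1.2-fold higher number from compound 3 to compound 4 (0.07 log units; within the scatter) and so no readable change. The chlorine is therefore not required for a number to be read in this assay, at least within this pair. Against the two compounds that stand at limits, the new compound adds only an at least 1.1-fold lower number from compound 2 to compound 4 (0.06 log units; that floor lies within the scatter) and an at least 1.1-fold lower number from compound 1 to compound 4 (0.05 log units; that floor lies within the scatter), so 3,5-dimethylphenyl cannot be set apart from 4-(methoxymethyl)phenyl or 4-(methylsulfanyl)phenyl any more firmly than 3-chloro-4-methylphenyl could.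

On these data alone, whether a phenyl bearing an amine or a carboxylic acid, or a longer chain such as butyl in place of the methyl groups, would carry the number beyond the scatter remains open. Nothing shown gives a reason why compound 3 and compound 4 read so alike.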